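A Methyl Group and the Amount Left

The source may hold more compounds than are shown below. What is called first, only, known or untested is meant among the compounds shown, and "the series" means these compounds.

Compound 1 `C[C@H](Nc1ncnc2[nH]cnc12)c1cc2ccccn2c(=O)c1-c1ccccc1` and compound 3 `C[C@H](Nc1nc(N)nc(N)c1C#N)c1cc2ccc(F)cn2c(=O)c1-c1ccccc1` share much of their shape, but they are built on two different cores, and the difference between the two cores is not broken down here. Both were tested in an ADME assay on microsomes from liver (Mus musculus), read by LC-MS, using NADPH, with a stated time of 30 min, tested at 1 uM; a higher number here means that more of the compound is left, a lower number that less of the compound is left. Compound 1 gives 51%, and compound 3 gives 42%; these two numbers lie within the usual scatter of each other, so no order between them can be read.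

Compound 2 `Cc1cccc2cc([C@H](C)Nc3ncnc4[nH]cnc34)c(-c3ccccc3)c(=O)n12` differs from compound 1 by methyl in place of hydrogen on an aromatic carbon. In this assay compound 2 gives 4%, which makes the step of a number 47 percentage points lower from compound 1 to compound 2 (beyond the scatter).

Compound 4 `Cc1c([C@H](C)Nc2nc(N)nc(N)c2C#N)c(-c2ccccc2)c(=O)n2cc(F)ccc12` has not yet been measured. It differs from compound 3 by methyl in place of hydrogen on an aromatic carbon. Going by the values given here, this is the same kind of change as the one from compound 1 to compound 2, not the same change: in compound 2 the methyl sits next to the ring nitrogen, whereas in compound 4 it sits two atoms from the ring nitrogen, ortho to a large group, meta to a phenyl group and para to a group of 1 heavy atom.

Among the compounds with values here, because the only measured example of this kind of change is a number 47 percentage points lower from compound 1 to compound 2 (beyond the scatter), a fall is expected for compound 4 as well, though the different surroundings of the methyl leave the size uncertain. The expected step is a number 24 percentage points lower from compound 3 to compound 4 (beyond the scatter). Compound 4 is therefore estimated at 18%, most likely between 3% and 42%.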

Compound 4, percent of the compound remaining: 85%
Estimate against measurement, compound 4: 67 percentage points below, outside the stated range (above it).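

Placing a methyl on an aromatic carbon, two atoms from the ring nitrogen, gives in this assay a number 43 percentage points higher from compound 3 to compound 4 (beyond the scatter), and more of compound 4 is left after the incubation, not less. Set beside the earlier example, the outcome of this kind of change clearly did not carry from one core to the other, and even its direction was reversed: the same change on two cores in this assay, a number 47 percentage points lower (beyond the scatter) from compound 1 to compound 2 and a number 43 percentage points higher (beyond the scatter) from compound 3 to compound 4, 90 percentage points apart, beyond the scatter of two such steps. This does not show that the core alone decides the outcome, for the two pairs differ both in their core and in where the methyl sits on the ring, and with one pair for each case these two differences cannot be told apart, nor can any general rule for the series be drawn.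

From the compounds shown here alone, it stays open whether a methyl at the place it holds in compound 4 would give a rise on the core of compound 1, and whether a methyl at the place it holds in compound 2 would give a fall on the core of compound 3. Going by these compounds, it is also open how an ethyl group, a methoxy group or a chlorine atom at either place would read in this assay.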